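A few compounds are considered here, and "the series" means these few. Any claim that something is new, unique, unknown or untested is made for them only; others in the source may bear on it.

Compound 1 `CCCOCCn1c(N2CCN(C)CC2)nc2ccccc21` and compound 2 `CCCCN1CCN(c2nc3ccccc3n2CCOCC)CC1` share one core and differ in a single group. For the measured compounds named here, in a functional assay on ileum for inhibition of histamine H1 receptor (Cavia porcellus) (a higher number here means a weaker inhibitor, a lower number a stronger inhibitor), compound 1 gives 20 nM, the higher of the two numbers so far, while compound 2 gives 15 nM, a gap that lies within the scatter. Compound 3 `C#CCOCCn1c(N2CCN(C)CC2)nc2ccccc21` is not yet measured; it differs from compound 1 by ethynyl in place of ethyl on a saturated chain carbon bound to an oxygen on a saturated carbon. Going by the values given here, no step between measured compounds speaks to such a change, so the expected step is small, a 1.3-fold higher number from compound 1 to compound 3 (0.10 log units; within the scatter), with no direction beyond the scatter. Compound 3 is therefore expected to give about 25 nM, within 8 nM to 80 nM.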

Compound 3, half-maximal inhibitory concentration: 12 nM
The estimate for compound 3 lay 2.1-fold (0.32 log units) above the measured number; measured number inside the range.
By their numbers in this assay, from the lowest: compounds 3, 2 and 1 (each within the scatter of the next).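

In this assay the change of ethyl to ethynyl on a saturated chain carbon bound to an oxygen on a saturated carbon gives a 1.7-fold lower number from compound 1 to compound 3 (0.22 log units; within the scatter) and this step lies within the scatter. The propoxy and propargyloxy forms therefore cannot be told apart here, and the triple bond brings no change that can be read. Nothing available explains this result. Going by these compounds, whether a longer chain, a phenyl ring or an amine on that same carbon would move the number beyond the scatter remains open.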